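The source may hold more compounds than are shown below. What is called first, only, known or untested is meant among the compounds shown, and "the series" means these compounds.

Measured so far in an ADME assay on Huh-7 cells (Homo sapiens) for cytotoxicity; a lower number here means that less compound is tolerated, a higher number that more compound is tolerated:
- Compound 1 `Cc1ccccc1-c1nn(-c2ccc(F)cc2F)cc1CNCCCCO`; compound 1 gives > 20000 nM, which is a limit of the assay.
- Compound 2 `CCCN1CCC(CNCc2cn(-c3ccc(F)cc3F)nc2-c2ccccc2C)CC1`; compound 2 gives > 20000 nM, which is a limit of the assay.

Going by the values given here, compound 2 therefore stands at the limit in this assay; no number is known for it, and the same holds for its only measured neighbour, see (the limit of > 20000 nM in this assay, at which 2 of the 2 values shown sit).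

Compound 3 `Cc1ccccc1-c1nn(-c2ccc(F)cc2F)cc1CNC1CCN(S(C)(=O)=O)CC1` is the next member to be measured. Its change against compound 2 is 1-(methylsulfonyl)piperidin-4-yl in place of (1-propylpiperidin-4-yl)methyl on an amine nitrogen.

Among the compounds with values here, only one measured step exists, a step that the two limits leave unreadable from compound 1 to compound 2, and that step is unreadable in size, since both of its ends are limits. Within the data shown here, no measured step therefore gives a readable size that bears on the change from compound 2 to compound 3. Two of two compounds sit at the limit, so the working expectation for compound 3 is that it, too, is tolerated up to the limit, with a step of a number no higher from compound 2 to compound 3 (the limit leaves the size open) expected, none beyond the scatter. On that basis compound 3 is estimated at 20000 nM, within a range from 10000 nM to 40000 nM.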

Compound 3, half-maximal cytotoxic concentration: > 20000 nM
Compound 3 gave a limit, no number; the forecaster's own chance of this, stated with the estimate: 80%; the middle value lies on the limit itself.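

In this assay compound 3 gives > 20000 nM, which is a limit of the assay. Going by these compounds alone, no step among compound 1, compound 2 and compound 3 can be read in size: the limit of > 20000 nM in this assay, at which 3 of the 3 values shown sit. The compounds shown leave open where the actual value of each lies, and whether any of these changes on the amine nitrogen shifts tolerance at all.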